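Working notes on a chloro-bromo pair and pending analogue

The source may hold more compounds than are shown below. What is called first, only, known or untested is meant among the compounds shown, and "the series" means these compounds.

Compound 1 `O=C(CN1CCCCC1)Nc1ccc2ncnc(Nc3cccc(Cl)c3)c2c1`: in a functional assay on MCF7 cells (Homo sapiens) for antiproliferative activity, read by MTT assay, with a stated time of 48 h (on this read-out higher numbers stand for weaker inhibition and lower numbers for stronger inhibition), compound 1 gives > 100000 nM, a limit of the assay and not a number.
Compound 2 `CN1CCN(CC(=O)Nc2ccc3ncnc(Nc4cccc(Cl)c4)c3c2)CC1`: in this assay compound 2 gives > 100000 nM, again a limit of the assay.
For the measured compounds named here, compound 3 `O=C(CN1CCCCC1)Nc1ccc2ncnc(Nc3cccc(Br)c3)c2c1`: in this assay compound 3 gives 3000 nM, the only number so far.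

The two cores differ by bromo in place of chloro on an aromatic carbon, and this change made the step of an at least 33-fold lower number from compound 1 to compound 3 (1.52 log units; beyond the scatter). The change from compound 1 to compound 2 is 4-methylpiperazin-1-yl in place of piperidin-1-yl on a saturated chain carbon bound to a carbonyl carbon; its step is a step that the two limits leave unreadable from compound 1 to compound 2, since both values sit at the limit of > 100000 nM in this assay, at which 2 of the 3 values shown sit. Compound 4 `CN1CCN(CC(=O)Nc2ccc3ncnc(Nc4cccc(Br)c4)c3c2)CC1` is not yet measured. It differs from compound 3 by 4-methylpiperazin-1-yl in place of piperidin-1-yl on a saturated chain carbon bound to a carbonyl carbon, the same change as from compound 1 to compound 2, at the same place. That earlier step gives no readable size, so the expectation for compound 4 rests only on compound 3 at 3000 nM and on an unknown direction for the change. The expected step is a 1.3-fold higher number from compound 3 to compound 4 (0.12 log units; within the scatter), with wide uncertainty. Compound 4 is estimated at 4000 nM, expected between 1000 nM and 30000 nM.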

Compound 4, half-maximal inhibitory concentration: 10000 nM
Compound 4: the middle estimate sits 2.5-fold (0.40 log units) below what was measured, within the range that was stated.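

Bromo in place of chloro gives a lower number in both matched pairs, and the new pair shows an at least 10-fold lower number from compound 2 to compound 4 (1.00 log units; beyond the scatter), so the direction holds on both cores in this assay: the same change on two cores in this assay, an at least 33-fold lower number (1.52 log units; beyond the scatter) from compound 1 to compound 3 and an at least 10-fold lower number (1.00 log units; beyond the scatter) from compound 2 to compound 4; the limit leaves it open whether they differ

On these data alone, compound 1 and compound 2 each sit at a limit of the assay and not at a number, so the true size of this change on either core stays unknown, and the steps that rest on two limits cannot be read. On the core of compound 3, 4-methylpiperazin-1-yl in place of piperidin-1-yl gives a 3.3-fold higher number from compound 3 to compound 4 (0.52 log units; beyond the scatter), but there is no readable counterpart on the core of compound 1, so the carrying of this second change from one core to the other is not shown.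

As far as these compounds go, it remains open whether iodo, methyl or trifluoromethyl in place of bromo on the aromatic carbon would continue the trend of the two matched pairs. Also open, from the compounds shown here alone, is how morpholin-4-yl, dimethylamino or a longer chain would compare with piperidin-1-yl.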